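From Acetyl to Ethoxycarbonyl on the Shared Core

The source may report more compounds than this note shows. Statements on the series, on what has been measured and on what is new or still open speak of the compounds shown alone.

In a functional assay on Caco-2 cells (Homo sapiens) for antiproliferative activity, with a stated time of 48 h (on this read-out higher numbers stand for weaker inhibition and lower numbers for stronger inhibition), compound 3 (`CCN(CC)c1ccc(-c2ccc(C(C)=O)cc2)nn1`) gives 15000 nM. Of the two exact numbers available, this is the lower, and compound 1 (`CC(=O)c1ccc(-c2ccc(N3CCCC3)nn2)cc1`) gives 50000 nM. Compound 2 (`CCN(CC)c1ccc(-c2ccc(C#N)cc2)nn1`) is reported only as a limit, > 25000 nM.

Compound 4 (`CCOC(=O)c1ccc(-c2ccc(N(CC)CC)nn2)cc1`) keeps the shared core and the diethylamino group of compound 3 and changes one thing: ethoxy in place of methyl on a carbonyl carbon. Within the data shown here, no measured step makes this exchange of acetyl to ethoxycarbonyl, so the evidence is indirect. The closest step replaces cyano with acetyl on an aromatic carbon and gives an at least 1.6-fold lower number from compound 2 to compound 3 (0.22 log units; that floor lies within the scatter), a floor that lies within the scatter. The other step, a 3.3-fold lower number from compound 1 to compound 3 (0.52 log units; beyond the scatter), is modest but beyond the scatter. It exchanges pyrrolidin-1-yl for diethylamino, a group that compound 4 leaves untouched, so it says little about the carbonyl substituent.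

With only the small step from compound 2 to guide it, the expectation in this assay is for no change beyond the scatter, with a slight rise the more likely direction. The estimated change is a 1.2-fold higher number from compound 3 to compound 4 (0.08 log units; within the scatter). For compound 4 the expected value is 18000 nM, with an estimated range of 7000 nM to 45000 nM.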

Compound 4, half-maximal inhibitory concentration: 4000 nM
Compound 4: the middle estimate sits 4.5-fold (0.65 log units) above what was measured; measured number below the stated range.
By their numbers in this assay, from the lowest: compound 4; then compound 3; then compound 1.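

In this assay, among these compounds, the substituent on a carbonyl carbon whose other neighbour is an aromatic carbon proves to matter: ethoxy in place of methyl gives a 3.8-fold lower number from compound 3 to compound 4 (0.57 log units; beyond the scatter), a step beyond the scatter at a place the earlier compounds had not varied. Ethoxycarbonyl in place of cyano on the aromatic carbon gives an at least 6.2-fold lower number from compound 2 to compound 4 (0.79 log units; beyond the scatter), so this step clears the scatter, whereas the floor of the step from cyano to acetyl did not. Compound 2 stands only as a limit, which makes that step a floor and not a measured size: the limit of > 25000 nM in this assay, at which 1 of the 4 values shown sits.

The compounds shown do not separate the added oxygen from the added ethyl chain, and a methyl ester, a propyl ketone, a carboxylic acid or an amide on the same carbonyl carbon would bear on that question. As far as these compounds go, it also remains open whether the gain from methyl to ethoxy carries over to the pyrrolidin-1-yl series, since here it rests on a single pair that keeps the diethylamino group.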